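This account rests on a few compounds, and the source may have more. Where it says the series, first, only, none or still open, it means among the compounds named here.

Compound 1 `NS(=O)(=O)Oc1ccc2c(c1)CN(C(=O)c1ccc(N(Cc3ccccc3)Cc3ccco3)cc1)CC2` gives 90.8% in an assay on HEK293 cells for inhibition of Steryl-sulfatase (Homo sapiens), tested at 0.1 uM; a lower number here means a weaker effect, a higher number a stronger effect of the compound at the concentration tested.
Compound 2 `CCN(Cc1ccccc1)c1ccc(C(=O)N2CCc3ccc(OS(N)(=O)=O)cc3C2)cc1` gives 66.9% in this assay.
Compound 3 `CCCN(Cc1ccccc1)c1ccc(C(=O)N2CCc3ccc(OS(N)(=O)=O)cc3C2)cc1` gives 64.8% in this assay.

Compound 3 has the lowest of the three numbers, but its neighbour compound 2 is close: the step of a number 2.1 percentage points lower from compound 2 to compound 3 (within the scatter) lies within the usual scatter, so the two cannot be told apart. The distance to compound 1 is real, as the step of a number 26 percentage points lower from compound 1 to compound 3 (beyond the scatter) shows, and the parallel step a number 23.9 percentage points lower from compound 1 to compound 2 (beyond the scatter) points the same way.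

Compound 4 `CN(C)CCCN(Cc1ccccc1)c1ccc(C(=O)N2CCc3ccc(OS(N)(=O)=O)cc3C2)cc1` is not yet measured. It differs from compound 3 by dimethylamino in place of hydrogen on a saturated chain carbon, three bonds along the chain from a nitrogen on an aromatic ring. Among the measured compounds shown here, no measured step touches this part of the molecule beyond the chain itself; the only related step, a number 2.1 percentage points lower from compound 2 to compound 3 (within the scatter), was a lengthening of that chain by one carbon and stayed within the scatter. On that thin basis, no step beyond the scatter is expected in this assay, but the uncertainty is wide. For compound 4 the expected value is 60%, with a range from 35% to 85%. This means an expected step of a number 4.8 percentage points lower from compound 3 to compound 4 (within the scatter).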

Compound 4, a percentage reported as inhibition, at one concentration (the size of the read-out at that concentration, not a potency): 16.2%
Beside the measured number, compound 4's estimate is 43.8 percentage points above it; the whole stated range lies above it.
By their numbers in this assay, from the lowest: compound 4; then compounds 3 and 2 (each within the scatter of the next); then compound 1.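

Lengthening the chain from ethyl to propyl had shown nothing beyond the scatter, so the chain looked free to grow, yet ending it in dimethylamino gives the step of a number 48.6 percentage points lower from compound 3 to compound 4 (beyond the scatter) in this assay. The same gap appears against the shorter chain, with the step of a number 50.7 percentage points lower from compound 2 to compound 4 (beyond the scatter), and against the furan-bearing compound, with the step of a number 74.6 percentage points lower from compound 1 to compound 4 (beyond the scatter), so what sits at the end of this chain matters, not just its length. Nothing available here explains the size of this step.

On these data alone, it remains open whether the loss belongs to the amine itself or to any added group at this chain end. A chain ending in a hydroxyl group, a carboxylic acid or a morpholine, or a longer chain carrying the same dimethylamino group, would help separate these possibilities.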